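Adding cyclopropyl to the ring amine of compound 1

The compounds below may be only part of what the source reports. "The series", "measured", "known", "first", "only" and "open" are said of these compounds alone.

Within the data shown here, in an ADME assay on microsomes from liver (Rattus norvegicus) for metabolic stability, read by LC-MS, with a stated time of 10 min, tested at 0.5 uM (a higher number here means that more of the compound is left, a lower number that less of the compound is left), compound 1 `c1ccc2c(c1)CN[C@@H](CN(CCCN1CCNCC1)[C@H]1CCCc3cccnc31)C2` gives 100%, the highest of the three numbers so far. Compound 3 `c1cnc2c(c1)CN[C@@H](CN(CCCN1CCNCC1)[C@H]1CCCc3cccnc31)C2` gives 79%. Compound 2 `c1cnc2c(c1)CCC[C@@H]2N(CCCN1CCNCC1)Cc1cc2ccccc2cn1` gives 59%.

The measured steps are a number 41 percentage points lower from compound 1 to compound 2 (beyond the scatter), which is large, and a number 21 percentage points lower from compound 1 to compound 3 (beyond the scatter) and a number 20 percentage points higher from compound 2 to compound 3 (beyond the scatter), which are both modest. All three lie beyond the scatter, and all three change the group on a saturated chain carbon bound to an amine nitrogen.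

Compound 4 `c1ccc2c(c1)CN[C@@H](CN(CCCN1CCN(C3CC3)CC1)[C@H]1CCCc3cccnc31)C2` keeps that group and changes another place: cyclopropyl in place of hydrogen on an amine nitrogen in a ring. This puts cyclopropyl in place of hydrogen on an amine nitrogen in a ring. Among the measured compounds shown here, no measured step touches this nitrogen, so the steps above bear on it only as a guide to size, and the direction rests on where compound 1 stands. With compound 1 at 100%, the read-out leaves almost no room upward, so a modest downward step is expected.

The estimated step is a number 22 percentage points lower from compound 1 to compound 4 (beyond the scatter). For compound 4 the expected value is 78%, with an estimated range from 50% to 100%.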

Compound 4, percent of the compound remaining: 2%
Beside the measured number, compound 4's estimate is 76 percentage points above it, outside the stated range (below it).
By their numbers in this assay, from the lowest: compound 4; then compound 2; then compound 3; then compound 1.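

In this assay, the ring amine nitrogen proves to be a highly sensitive position: cyclopropyl in place of hydrogen gives a number 98 percentage points lower from compound 1 to compound 4 (beyond the scatter) and leaves almost none of the compound. This step is larger than a number 41 percentage points lower from compound 1 to compound 2 (beyond the scatter), the largest change seen from the group on the saturated chain carbon, so a small group of carbon atoms at this nitrogen can outweigh the earlier changes at that other place. Nothing measured here accounts for the drop.

With hydrogen and cyclopropyl the only groups shown on this nitrogen, it remains open whether a methyl, an isopropyl or an acetyl group would give a similarly low number. Also open, from the compounds shown here alone, is whether the same cyclopropyl change would give a step of this size on the cores of compound 2 and compound 3.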